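The compounds below may be only part of what the source reports. "The series", "measured", "known", "first", "only" and "open" are said of these compounds alone.

Compound 1 `COc1cc2nc(N3CCC(N4CCCC(CO)C4)CC3)nc(NCc3ccc(Cl)cc3)c2cc1OC`: 140 nM
Compound 2 `COc1cc2nc(N3CCC(N4CCCC(CO)C4)CC3)nc(NC3CCOCC3)c2cc1OC`: "not determined" (no result reported)
Compound 3 `COc1cc2nc(N3CCC(N4CCCC(CO)C4)CC3)nc(NC3CCS(=O)(=O)CC3)c2cc1OC`: "not determined" (no result reported)

Three compounds share one core and differ only in the group attached to a nitrogen on an aromatic ring. In an in vitro functional assay on B300-19 cells for antagonist activity at C-C chemokine receptor type 4 (Mus musculus) (on this read-out lower numbers stand for stronger inhibition and higher numbers for weaker inhibition), compound 1 gives 140 nM. In this assay, among the measured compounds shown here, compound 2 gives "not determined" (no result reported) and compound 3 gives "not determined" (no result reported), so compound 2 stands without a value of its own, and no step between two measured compounds can be read from this set.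

Compound 4 `COc1cc2nc(N3CCC(N4CCCC(CO)C4)CC3)nc(Nc3ccc(Cl)cc3)c2cc1OC` has not yet been measured. It arises from compound 2 through (4-chlorophenyl in place of oxan-4-yl on a nitrogen on an aromatic ring). The group that leaves is oxan-4-yl, a six-membered non-aromatic ring with one hetero atom; the group that enters is 4-chlorophenyl, a six-membered aromatic ring of carbon only.

Since compound 2 has no number, no direction or size can be claimed for the step in this assay from compound 2 to compound 4. For the measured compounds named here, the only anchor is compound 1, which carries a 4-chlorophenyl group on a carbon attached to the same nitrogen and gives a measured value. Compound 4 is therefore expected to land near that figure, with wide uncertainty: an estimated 300 nM, likely between 60 nM and 2000 nM.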

Compound 4, half-maximal inhibitory concentration: 58 nM
The estimate for compound 4 lay 5.2-fold (0.71 log units) above the measured number; measured number outside the range, below it.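

In this assay, putting 4-chlorophenyl in place of 4-chlorobenzyl on the nitrogen gives a 2.4-fold lower number from compound 1 to compound 4 (0.38 log units; beyond the scatter), a modest change but one beyond the scatter of repeated measurements. Among the compounds shown here, this is the first comparison at this position with a number on both sides, and it shows that the chlorine-bearing ring need not be held away from the nitrogen by a carbon for activity to be kept: in this pair, the directly attached ring gives the lower number. No measurement shown here explains this difference.

For the compounds shown here, compound 2 and compound 3 have no numbers, so no step to or from either can be read, and it remains unknown how a non-aromatic ring such as oxan-4-yl performs at this nitrogen. Also open, going by these compounds, is whether the trend seen in this single pair would continue with a longer chain such as 2-(4-chlorophenyl)ethyl, and whether chlorine itself matters, which a plain phenyl group or a methoxy group in its place could test.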